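Methyl for isopropyl on a shared core

The source may hold more compounds than are shown below. What is called first, only, known or untested is meant among the compounds shown, and "the series" means these compounds.

In a functional assay on HBL-100 cells (Homo sapiens) for antiproliferative activity, read by sulforhodamine B assay, with a stated time of 48 h (a higher number here means a weaker inhibitor of growth, a lower number a stronger inhibitor of growth), compound 1 `CCC(C)C(C#CC(=O)OC)O/C=C/C(=O)OC` gives 340 nM, compound 2 `COC(=O)C#CC(O/C=C/C(=O)OC)C1CC1` gives 250 nM and compound 3 `COC(=O)C#CC(O/C=C/C(=O)OC)C(C)C` gives 450 nM. Compound 3 therefore stands within the scatter of both others, with a 1.3-fold higher number from compound 1 to compound 3 (0.12 log units; within the scatter) and a 1.8-fold higher number from compound 2 to compound 3 (0.26 log units; within the scatter). The remaining comparison, a 1.4-fold lower number from compound 1 to compound 2 (0.13 log units; within the scatter), is also within the scatter. Compound 4 `COC(=O)C#CC(C)O/C=C/C(=O)OC` carries methyl in place of isopropyl on a saturated chain carbon bound to an oxygen on an unsaturated carbon and a triple-bonded carbon. For the measured compounds named here, none of the measured compounds carries methyl there, so the range stays wide. No step beyond the scatter is expected in this assay. The expected step is a 1.1-fold higher number from compound 3 to compound 4 (0.05 log units; within the scatter). For compound 4 the estimated value is 500 nM, with an expected range of 220 nM to 1200 nM.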

Compound 4, concentration for 50% growth inhibition: 300 nM
For compound 4 the middle estimate is 1.7-fold (0.22 log units) above the measured one; the range from low to high includes it.
By their numbers in this assay, from the lowest: compounds 2, 4, 1 and 3 (each within the scatter of the next).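

In this assay methyl on this saturated chain carbon stays within the scatter of all three other groups: isopropyl (a 1.5-fold lower number from compound 3 to compound 4 (0.18 log units; within the scatter)), cyclopropyl (a 1.2-fold higher number from compound 2 to compound 4 (0.08 log units; within the scatter)) and sec-butyl (a 1.1-fold lower number from compound 1 to compound 4 (0.05 log units; within the scatter)). Cutting isopropyl down to methyl thus moves the number no further than the scatter, which the earlier compounds, none of which carries methyl, could not show. Nothing given here explains this result.

All four compounds carry only carbon groups at this position. Going by these compounds, whether an amine, a carboxylic acid or a longer chain there would leave the number within the scatter remains open.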